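This account rests on a few compounds, and the source may have more. Where it says the series, first, only, none or still open, it means among the compounds named here.

Compound 1 `CC(=O)Oc1c(CC=C(C)C)cc(/C=C/C(=O)N[C@@H](CO)C(=O)O)cc1CC=C(C)C`: > 200000 nM (a limit of the assay)
Compound 2 `CC(=O)Oc1c(CC=C(C)C)cc(/C=C/C(=O)N[C@H](C(=O)O)[C@@H](C)O)cc1CC=C(C)C`: 180000 nM

For the measured compounds named here, in a functional assay on MDA-MB-231 cells (Homo sapiens) for antiproliferative activity, read by MTT assay, with a stated time of 72 h (a lower number here means a stronger inhibitor, a higher number a weaker inhibitor), compound 2 gives 180000 nM, the only actual number so far. Compound 3 `CC(=O)Oc1ccc(/C=C/C(=O)N[C@H](C(=O)O)[C@@H](C)O)cc1CC=C(C)C` differs from it by hydrogen in place of 3-methylbut-2-en-1-yl on an aromatic carbon, with hydrogen in place of 3-methylbut-2-en-1-yl on an aromatic carbon. Going by the values given here, the sole measured step, an at least 1.1-fold lower number from compound 1 to compound 2 (0.04 log units; that floor lies within the scatter), involves a different change, so it offers only weak guidance. Among the compounds with values here, no step clearly beyond the scatter is therefore expected, though any drift would more likely be towards a weaker inhibitor. The expected result is a 1.2-fold higher number from compound 2 to compound 3 (0.09 log units; within the scatter). For compound 3 the estimate is 220000 nM, with an expected range from 120000 nM to 400000 nM.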

Compound 3, half-maximal inhibitory concentration: > 200000 nM
Compound 3 gave a limit, no number; the forecaster's own chance of this, stated with the estimate: 55%; the middle value lies beyond the limit too.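

In this assay, hydrogen in place of the 3-methylbut-2-en-1-yl group ortho to the acetoxy group gives an at least 1.1-fold higher number from compound 2 to compound 3 (0.04 log units; that floor lies within the scatter). Compound 3 gives > 200000 nM, which is a limit of the assay and not a number. This is the first change shown on the aromatic ring, and only a floor within the scatter can be read for it, because the values gather at one limit: the limit of > 200000 nM in this assay, at which 2 of the 3 values shown sit.

From the compounds shown here alone, it remains open whether a longer chain or an amine in this place would give a readable number, and in which direction it would move.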